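Swapping One Side Group on the Strongest Growth Inhibitor

The compounds below may be only part of what the source reports. "The series", "measured", "known", "first", "only" and "open" are said of these compounds alone.

Of the compounds shown here, three have been measured so far in a functional assay on MV4-11 cells (Homo sapiens) for inhibition, read by resazurin assay, with a stated time of 72 h (a lower number here means a stronger inhibitor of growth, a higher number a weaker inhibitor of growth), and two of them sit close together. There compound 1 (`CCn1cc(-c2ccnc(Nc3ccc(OC)cc3OC)n2)c2ccccc21`) gives 3590 nM and compound 3 (`COc1ccc(Nc2nccc(-c3c[nH]c4ccccc34)n2)c(OC(F)F)c1`) gives 4770 nM as its result. Compound 2 (`COc1ccc(Nc2nccc(-c3sc(SC)nc3C)n2)c(OC)c1`) gives 530 nM and so holds the lowest of the three numbers, with both others beyond the scatter. That makes it the strongest inhibitor of growth in this small set.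

Compound 4 (`COCCOc1nc(C)c(-c2ccnc(Nc3ccc(OC)cc3OC)n2)s1`) differs from compound 2 at one place: on an aromatic carbon of a five-membered aromatic ring with 1 nitrogen and 1 sulfur, 2-methoxyethoxy stands in place of methylsulfanyl (2-methoxyethoxy in place of methylsulfanyl on an aromatic carbon). Going by the values given here, no two measured compounds differ in only one place, so nothing here shows directly what such a swap does. Compound 2 at 530 nM already sits at the low end of the set, so there seems more room for the number to rise than to fall. In this assay a small step toward weaker inhibition is expected, estimated as a 1.7-fold higher number from compound 2 to compound 4 (0.23 log units; within the scatter) and possibly no larger than the scatter. The estimated value for compound 4 is 900 nM with 250 nM to 3500 nM as the expected range.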

Compound 4, concentration for 50% growth inhibition: 1980 nM
Compound 4: the middle estimate sits 2.2-fold (0.34 log units) below what was measured; low and high end bracket the measured number.
By their numbers in this assay, from the lowest: compound 2; then compounds 4, 1 and 3 (each within the scatter of the next, the first and the last beyond it).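

Going by these compounds alone, this is the first direct comparison in the set, and it shows that this place on the five-membered aromatic ring with 1 nitrogen and 1 sulfur, next to the ring nitrogen and next to the ring sulfur, is sensitive to the group it carries. In this assay, putting 2-methoxyethoxy in place of methylsulfanyl gives a 3.7-fold higher number from compound 2 to compound 4 (0.57 log units; beyond the scatter), a modest step that weakens growth inhibition without removing it. The swap replaces a group of 2 heavy atoms containing sulfur with one of 5 heavy atoms containing oxygen, and no available data explain why the number rises.

With size and atom type changing together in a single pair, the compounds shown leave open which of the two matters, and a methoxy group or an ethylsulfanyl group at the same place could help pull them apart. They also leave open how this place responds to a group of another kind, such as a dimethylamino group, a carboxylic acid or a longer chain ending in an amine.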